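Restoring an Ortho-Type Pattern: Compound 3 to Compound 4

The source may report more compounds than this note shows. Statements on the series, on what has been measured and on what is new or still open speak of the compounds shown alone.

Measured compounds:
Compound 1, `O=C(Nc1ccc(-c2cc(C(F)(F)F)ccc2Cl)cc1)c1c(F)cccc1F`: 8 nM
Compound 2, `CCc1ccc(C2=NOC(C)(C)C2=O)cc1-c1cnc(NC(=O)c2c(F)cccc2F)cn1`: 32 nM
Compound 3, `Cc1ccc(C2=NOC(C)(C)C2=O)cc1-c1cnc(NC(=O)c2ccc(F)cc2F)cn1`: "not active" (no number reported)

All three were tested in an assay on Jurkat T cells for inhibition of interleukin-2 (Homo sapiens), read by ELISA, with stated times of 10 min and 24 h; on this read-out lower numbers stand for stronger inhibition and higher numbers for weaker inhibition. Compound 1 gives 8 nM, and compound 2, which carries an ethyl on its core, gives 32 nM. Compound 3 is the odd one out: in this assay compound 3 was reported as "not active" (no number reported), so no number stands for it, and it cannot be placed on a scale beside the other two. Its amide bears a 2,4-difluorophenyl, whereas compound 1 and compound 2 both carry a 2,6-difluorophenyl on the same carbonyl carbon.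

Compound 4, `Cc1ccc(C2=NOC(C)(C)C2=O)cc1-c1cnc(NC(=O)c2c(F)cccc2Cl)cn1`, keeps the core of compound 3 and changes only the acyl part: 2-chloro-6-fluorophenyl in place of 2,4-difluorophenyl on a carbonyl carbon. This puts one halogen on each side of the carbonyl attachment, as in compound 1 and compound 2, rather than the pattern of compound 3. Among the compounds with values here, no measured pair in this set reports that single change, so its size is not known. Given the gulf between the inactive compound 3 and the active compound 2 at 32 nM, a step toward stronger inhibition is expected in this assay, with wide uncertainty. Compound 4 is estimated at 100 nM, within 15 nM to 1500 nM.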

Compound 4, half-maximal inhibitory concentration: 64.8 nM
Estimate against measurement, compound 4: 1.5-fold (0.19 log units) above; the measured number falls inside the stated range.
By their numbers in this assay, from the lowest: compound 1; then compound 2; then compound 4.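

In this assay, within the data shown here, compound 4 gives 64.8 nM but compound 3 has no number, so no step between compound 3 and compound 4 can be read. The compounds shown leave open how 2-chloro-6-fluorophenyl compares with 2,6-difluorophenyl on an otherwise identical core. Nothing shown here offers an explanation for this result.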